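The source may hold more compounds than are shown below. What is called first, only, known or untested is meant among the compounds shown, and "the series" means these compounds.

Three carbamates have been tested in a functional assay on CCRF-CEM cells (Homo sapiens) for cytotoxicity, read by MTT assay, with a stated time of 72 h; on this read-out lower numbers stand for stronger inhibition of growth and higher numbers for weaker inhibition of growth. Compound 1 `COc1ccc(OC(=O)Nc2ccc([Se]C#N)cc2)cc1` gives 41500 nM, compound 2 `CCCOC(=O)Nc1ccc([Se]C#N)cc1` gives 38400 nM, and compound 3 `CCCCCCOC(=O)Nc1ccc([Se][Se]c2ccc(NC(=O)OCCCCCC)cc2)cc1` gives 34400 nM. Compound 2 has the second highest of the three numbers; its nearest neighbour is compound 1 and its furthest is compound 3, and both gaps lie within the scatter, so the three compounds cannot be told apart on these data. Compound 4 `CCOC(=O)Nc1ccc([Se]C#N)cc1` has not yet been measured. It differs from compound 2 by hydrogen in place of methyl on a saturated chain carbon, two bonds along the chain from an oxygen next to a carbonyl group. Going by the values given here, no measured pair shows the effect of such a change, so the expectation in this assay is a step no larger than the scatter, in either direction. For compound 4 the expected value in this assay is 38000 nM, within 19000 nM to 76000 nM, which is estimated to mean a step of a 1.0-fold lower number from compound 2 to compound 4 (0.00 log units; within the scatter) that stays inside the scatter.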

Compound 4, concentration for total growth inhibition: 39100 nM
Beside the measured number, compound 4's estimate is 1.0-fold (0.01 log units) below it, and the stated range covers the measured number.
By their numbers in this assay, from the lowest: compounds 3, 2, 4 and 1 (each within the scatter of the next).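

Cutting the propyl chain to ethyl gives the first pair that isolates this position: in this assay, hydrogen in place of methyl gives a 1.0-fold higher number from compound 2 to compound 4 (0.01 log units; within the scatter) and so shows that this one carbon can go without a step that stands out from the scatter. Nothing measured here offers a reason for this result. From the compounds shown here alone, whether a longer chain, or an amine or a carboxylic acid on the chain, would give a number beyond the scatter stays open. This single step speaks only for the change from propyl to ethyl.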